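The compounds below may be only part of what the source reports. "The series", "measured", "known", "first", "only" and "open" are said of these compounds alone.

Among the measured compounds shown here, compound 3 `C[C@@H](O)[C@H](NC(=O)CN(c1ncnc2c1ncn2C1CCCCO1)C1CC1)C(=O)OCc1ccccc1` stands lowest of the three compounds measured so far in a functional assay on the whole organism (Tail, strain ICR) with Mus musculus as the target, in the tail flick test, with a stated time of 60 min, at a dose of 25 umol/kg by the oral route (a lower number here means a weaker effect, a higher number a stronger effect of the compound at the dose given), where compound 3 gives 28.4%. Compound 1 `O=C(CN(c1ncnc2c1ncn2C1CCCCO1)C1CC1)NCC(=O)OCc1ccccc1` gives 40.4%, and compound 2 `NCCCC[C@H](NC(=O)CN(c1nc(Cl)nc2[nH]cnc12)C1CC1)C(=O)OCc1ccccc1` gives 41.2%. For the measured compounds named here, the one measured step, a number 12 percentage points lower from compound 1 to compound 3 (beyond the scatter), describes a different change from the one now in question. Compound 4 `CC(C)[C@H](NC(=O)CN(c1ncnc2c1ncn2C1CCCCO1)C1CC1)C(=O)OCc1ccccc1` differs from compound 3 as follows: isopropyl in place of 1-hydroxyethyl on a saturated chain carbon bound to an amide-type nitrogen and a carbonyl carbon. Going by the values given here, no measured step touches isopropyl at this place, so the direction cannot be read from the data; the size of the known step suggests the change may be modest. Compound 4 is expected to give 35%, between 20% and 50%, a step of a number 6.6 percentage points higher from compound 3 to compound 4 (within the scatter).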

Compound 4, a percentage reported as activity, at one dose (the size of the read-out at that dose, not a potency): 34.9%
Compound 4: middle estimate off by 0.1 percentage points, on the high side, and the stated range covers the measured number.
By their numbers in this assay, from the lowest: compounds 3, 4, 1 and 2 (each within the scatter of the next, the first and the last beyond it).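

In this assay the step of a number 6.5 percentage points higher from compound 3 to compound 4 (within the scatter) replaces 1-hydroxyethyl with isopropyl on the saturated chain carbon bound to an amide-type nitrogen and a carbonyl carbon, and the step of a number 5.5 percentage points lower from compound 1 to compound 4 (within the scatter) puts isopropyl in place of hydrogen at the same place. Of the three groups compared here, only the change from hydrogen to 1-hydroxyethyl reaches beyond the scatter, while isopropyl stays within it of both. Nothing given here explains these numbers. As far as these compounds go, whether a carboxylic acid or a longer chain at this place would read differently stays open.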